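Cyclopropylamino for hydroxy: notes on compound 4

The source may report more compounds than this note shows. Statements on the series, on what has been measured and on what is new or still open speak of the compounds shown alone.

In a functional assay on CCRF-CEM cells (Homo sapiens) (on this read-out higher numbers stand for weaker inhibition and lower numbers for stronger inhibition), compound 2 `OC[C@H]1C[C@@H](Cn2cnc3c(O)ncnc32)c2ccccc21` gives 24 ug/mL and stands level with compound 1 `OC[C@H]1C[C@@H](Cn2cnc3c(Cl)ncnc32)c2ccccc21` at 24 ug/mL as the highest number of the three measured. Among the compounds with values here, compound 3 `Cn1ncc2c1[C@H](Cn1cnc3c(Cl)ncnc31)C[C@@H]2CO[Si](c1ccccc1)(c1ccccc1)C(C)(C)C` sits lower at 3.2 ug/mL but differs from both in more than one place and offers no single step. Compound 4 `OC[C@H]1C[C@@H](Cn2cnc3c(NC4CC4)ncnc32)c2ccccc21` differs from compound 2 as follows: cyclopropylamino in place of hydroxy on an aromatic carbon in words, cyclopropylamino in place of hydroxy on an aromatic carbon. Within the data shown here, the only measured step at that carbon shows no change at the digits printed from compound 1 to compound 2 (within the scatter) and no measured compound carries cyclopropylamino there. No step beyond the scatter is therefore expected, and the estimated step is a 1.2-fold lower number from compound 2 to compound 4 (0.08 log units; within the scatter) in this assay for now. Compound 4 is estimated at 20 ug/mL with an expected range from 6 ug/mL to 60 ug/mL for now.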

Compound 4, half-maximal inhibitory concentration: 24 ug/mL
Estimate against measurement, compound 4: 1.2-fold (0.08 log units) below, and the stated range covers the measured number.
By their numbers in this assay, from the lowest: compound 3; then compounds 1, 2 and 4 (each within the scatter of the next).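

In this assay, the aromatic carbon next to the ring nitrogen now carries a group with a three-membered ring, and the read-out gives no change at the digits printed from compound 2 to compound 4 (within the scatter) and no change at the digits printed from compound 1 to compound 4 (within the scatter). Chloro, hydroxy and cyclopropylamino at this carbon therefore lie within the scatter of one another on this core, which the single earlier step could not show for a larger ring-bearing group. Nothing available explains this flat response.

Going by these compounds, whether a longer amine chain or a carboxylic acid at this carbon would move the number remains open. Also open, on these data alone, is whether cyclopropylamino in place of chloro behaves the same way on the core of compound 3.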